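Propylsulfonyl on the amide nitrogen of compound 1

This account rests on a few compounds, and the source may have more. Where it says the series, first, only, none or still open, it means among the compounds named here.

Compound 1 `Cc1cc(C)cc(S(=O)(=O)c2c(C(N)=O)[nH]c3ccc(Cl)cc23)c1` is the parent of this small set. In an ADME assay on MT4 cells (Homo sapiens) for cytotoxicity, read by MTT assay, with a stated time of 5 days (a higher number here means that more compound is tolerated, a lower number that less compound is tolerated), compound 1 gives 13000 nM, the lowest of the three numbers measured. Compound 2 `Cc1cc(C)cc(S(=O)(=O)c2c(C(=O)NC3CN(CC(N)=O)C3)[nH]c3ccc(Cl)cc23)c1` gives 25500 nM, and compound 3 `Cc1cc(C)cc(S(=O)(=O)c2c(C(=O)NS(=O)(=O)C3CC3)[nH]c3ccc(Cl)cc23)c1` gives 147000 nM. The step of a 2.0-fold higher number from compound 1 to compound 2 (0.29 log units; within the scatter) stays within the scatter, whereas the step of an 11-fold higher number from compound 1 to compound 3 (1.05 log units; beyond the scatter) is large, and the step of a 5.8-fold higher number from compound 2 to compound 3 (0.76 log units; beyond the scatter) is modest.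

Compound 4 `CCCS(=O)(=O)NC(=O)c1[nH]c2ccc(Cl)cc2c1S(=O)(=O)c1cc(C)cc(C)c1` has not yet been measured in this assay. It differs from compound 1 by propylsulfonyl in place of hydrogen on an amide-type nitrogen. Going by the values given here, the measured step that bears most directly on this change is the one from compound 1 to compound 3, where cyclopropylsulfonyl entered on the same amide-type nitrogen and the number rose by an 11-fold higher number from compound 1 to compound 3 (1.05 log units; beyond the scatter). Propylsulfonyl occupies the same place with a chain of three carbons instead of a ring, so a step of similar direction and roughly similar size is expected. The step from compound 1 to compound 4 is therefore estimated as an 8.5-fold higher number from compound 1 to compound 4 (0.93 log units; beyond the scatter), a higher number in this assay. On that basis compound 4 is expected to give about 110000 nM, with a range from 40000 nM to 300000 nM.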

Compound 4, half-maximal cytotoxic concentration: 146000 nM
Compound 4: middle estimate off by 1.3-fold (0.12 log units), on the low side; measured number inside the range.
By their numbers in this assay, from the lowest: compounds 1 and 2 (each within the scatter of the next); then compounds 4 and 3 (each within the scatter of the next).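

In this assay, the large step seen with cyclopropylsulfonyl on the amide-type nitrogen does not depend on a ring in the group, as propylsulfonyl, which has no ring, gives an 11-fold higher number from compound 1 to compound 4 (1.05 log units; beyond the scatter) at the same place. Exchanging the two groups on the sulfonyl sulfur gives a 1.0-fold lower number from compound 3 to compound 4 (0.00 log units; within the scatter) and so leaves compound 3 and compound 4 indistinguishable in this measurement, which means that the cyclopropyl ring and the open propyl chain serve alike here. The second sulfonyl example also stands clear of the 1-(carbamoylmethyl)azetidin-3-yl group, with a 5.7-fold higher number from compound 2 to compound 4 (0.76 log units; beyond the scatter) on the same nitrogen, so in this set both compounds carrying a sulfonyl group on that nitrogen lie beyond the scatter of compound 1 and compound 2.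

The compounds shown leave open how far this tolerance extends on the sulfonyl sulfur, since a longer chain such as hexyl, a phenyl ring or an amine there could behave differently from propyl and cyclopropyl. Nothing in the material at hand accounts for the higher numbers of the sulfonyl compounds.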